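The compounds below may be only part of what the source reports. "The series", "measured", "known", "first", "only" and "open" are said of these compounds alone.

In a physicochemical assay for solubility, at pH 7 (a higher number here means a more soluble compound, a lower number a less soluble compound), compound 1 `CNC(=O)c1cc(Oc2ccc3nc(Nc4cccc(Br)c4)ncc3c2)ccn1` gives < 1000 nM, which is a limit of the measurement rather than a number. Compound 2 `CNC(=O)c1cc(Oc2ccc3nc(Nc4cccc(C(F)(F)F)c4)ncc3c2)ccn1` likewise gives only a limit, < 1000 nM. The step that the two limits leave unreadable from compound 1 to compound 2 is therefore not readable, since the limit of < 1000 nM in this assay, at which 2 of the 2 values shown sit, is where both values sit. Compound 3 `CNC(=O)c1cc(Oc2ccc3nc(Nc4ccc(F)cc4)ncc3c2)ccn1` differs from compound 2 by 4-fluorophenyl in place of 3-(trifluoromethyl)phenyl on a nitrogen on an aromatic ring. Within the data shown here, no measured step shows how this change acts, so the expectation rests on the two limits alone. Compound 3 is expected to give about 500 nM, estimated between 100 nM and 2000 nM, an expected step that the limit leaves unreadable from compound 2 to compound 3 that likely stays near the limit already seen.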

Compound 3, solubility: < 1000 nM
Compound 3 was reported as a limit; the forecaster's own chance of this, stated with the estimate: 70%; the middle value is on the limit's open side.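

No step among compound 1, compound 2 and compound 3 can be read in this assay, since each result is a limit and not a number: the limit of < 1000 nM in this assay, at which 3 of the 3 values shown sit.

From the compounds shown here alone, the true solubility of each compound, and whether these ring changes shift it, stays open.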